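Trading a Benzyloxy Group for a Carboxymethoxyphenyl Group

A few compounds are considered here, and "the series" means these few. Any claim that something is new, unique, unknown or untested is made for them only; others in the source may bear on it.

Measured compounds:
compound 1, `COc1ccc(C(OCc2ccccc2)c2cccc3ccccc23)c(OC)c1OC`: 13500 nM
compound 2, `COc1cc(COC(c2ccc(OC)c(OC)c2OC)c2cccc3ccccc23)cc(OC)c1`: 17500 nM

Both compounds were tested in a functional assay on A549 cells (Homo sapiens) for inhibition, read by sulforhodamine B assay, with a stated time of 48 h; on this read-out lower numbers stand for stronger inhibition and higher numbers for weaker inhibition. Compound 1 gives 13500 nM, and compound 2 gives 17500 nM. The single measured step, a 1.3-fold higher number from compound 1 to compound 2 (0.11 log units; within the scatter), is within the scatter, so on the numbers shown compound 1 and compound 2 cannot be told apart, and compound 1 has no claim to being stronger.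

Compound 3, `COc1ccc(C(c2ccc(OCC(=O)O)cc2)c2cccc3ccccc23)c(OC)c1OC`, differs from compound 1 in one place: 4-(carboxymethoxy)phenyl in place of benzyloxy on a saturated chain carbon bound to two aromatic carbons. The measured step changed only the benzyloxy part, which is exactly what leaves in compound 3, so nothing measured speaks to the entering group. In this assay no step beyond the scatter is therefore expected, only a wide uncertainty. The expected step is a 1.1-fold higher number from compound 1 to compound 3 (0.05 log units; within the scatter). Compound 3 is estimated at 15000 nM, within a range of 4000 nM to 60000 nM.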

Compound 3, half-maximal inhibitory concentration: 16400 nM
Beside the measured number, compound 3's estimate is 1.1-fold (0.04 log units) below it; the range from low to high includes it.
By their numbers in this assay, from the lowest: compounds 1, 3 and 2 (each within the scatter of the next).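

In this assay, putting 4-(carboxymethoxy)phenyl in place of benzyloxy gives a 1.2-fold higher number from compound 1 to compound 3 (0.08 log units; within the scatter). The earlier step altered only the ring of the benzyloxy group, whereas this change replaces the whole group, oxygen included, with a larger one that carries a hydrogen-bond donor, and still compound 1 and compound 3 cannot be told apart. No measurement shown here explains this result.

Every compound shown lies within the scatter of the others, so no group at this position has yet moved the number by a readable amount. From the compounds shown here alone, whether an amine or a methyl ester in place of 4-(carboxymethoxy)phenyl, on the saturated chain carbon bound to two aromatic carbons, would do so remains open.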